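Series notes: the step from compound 2 to compound 3

The source may hold more compounds than are shown below. What is called first, only, known or untested is meant among the compounds shown, and "the series" means these compounds.

Of the compounds shown here, two carry numbers so far. Compound 1 `NC(=O)c1c(NC(=O)c2ccccc2F)sc2c1CCN(Cc1cccc(Cl)c1)C2` and compound 2 `NC(=O)c1c(NC(=O)c2ccccc2Cl)sc2c1CCN(C(=S)Nc1cccc3ccccc13)C2` share a core and differ from each other in more than one place. In a functional assay on HL-60 cells (Homo sapiens) for antiproliferative activity, with a stated time of 24 h (on this read-out higher numbers stand for weaker inhibition and lower numbers for stronger inhibition), compound 1 gives 19800 nM. In this assay compound 2 gives 13400 nM, the lower of the two numbers, though the pair lies within the scatter of repeated measurement, so no order between them is claimed.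

Compound 3 `NC(=O)c1c(NC(=O)c2ccccc2Cl)sc2c1CCN(C(=S)Nc1cccnc1)C2` is not yet measured. It differs from compound 2 in one place: pyridin-3-yl in place of naphthalen-1-yl on an amide-type nitrogen. Within the data shown here, no step between measured compounds bears on this change, so the numbers at hand give no direction for it. With both measured numbers sitting close together and high, the expected step is a 1.6-fold higher number from compound 2 to compound 3 (0.22 log units; within the scatter), staying within the scatter or leaning toward weaker inhibition. Compound 3 is estimated in this assay at 22000 nM, with a range from 7000 nM to 70000 nM.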

Compound 3, half-maximal inhibitory concentration: 33900 nM
Beside the measured number, compound 3's estimate is 1.5-fold (0.19 log units) below it; low and high end bracket the measured number.
By their numbers in this assay, from the lowest: compounds 2, 1 and 3 (each within the scatter of the next, the first and the last beyond it).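

Among these compounds, at the amide-type nitrogen whose other neighbour is the thiocarbonyl carbon, pyridin-3-yl in place of naphthalen-1-yl gives the first single-place step: in this assay it produces a 2.5-fold higher number from compound 2 to compound 3 (0.40 log units; beyond the scatter), which on this read-out means weaker inhibition. This position therefore does not treat the two aromatic groups as interchangeable, and the group with one ring and one hydrogen-bond acceptor sits on the weaker side. The change alters ring count and ring nitrogen together, and nothing at hand gives a reason for the step.

From the compounds shown here alone, whether the step follows the lost second ring or the ring nitrogen stays open, and a phenyl group on the same nitrogen would separate the two. Also open, going by these compounds, is how a cyclohexyl group or a short alkyl chain would read at this place.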